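The source may report more compounds than this note shows. Statements on the series, on what has been measured and on what is new or still open speak of the compounds shown alone.

Of the compounds shown here, two share one core and have been measured. Compound 1 `CCOC(=O)c1sc(NC(=O)Cn2cc(-c3cccs3)nn2)nc1C` carries an ethoxycarbonyl group, while compound 2 `Cc1csc(NC(=O)Cn2cc(-c3cccs3)nn2)n1` has hydrogen in its place on an aromatic carbon. In a functional assay on BMDM cells (Mus musculus, strain C57BL/6) for inhibition, with a stated time of 2 days (a higher number here means a weaker inhibitor, a lower number a stronger inhibitor), compound 1 gives 20 nM, and compound 2 gives 40 nM. The step of a 2.0-fold higher number from compound 1 to compound 2 (0.30 log units; within the scatter) is the only one measured, and it leaves compound 1 with the lowest of the two numbers, though the gap is within the scatter, so neither compound can be called the stronger inhibitor.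

Compound 3 `CCOC(=O)c1sc(NC(=O)Cn2cc(-c3ccc(C#N)cc3)nn2)nc1C` differs from compound 1 elsewhere: 4-cyanophenyl in place of thiophen-2-yl on an aromatic carbon. Going by the values given here, no measured step touches this position, so the one known step gives no guidance, and the change must be judged without precedent. The expectation for compound 3 is therefore a step of a 2.0-fold higher number from compound 1 to compound 3 (0.30 log units; within the scatter), with wide uncertainty in either direction. Compound 3 is estimated at 40 nM, ranging from 10 nM to 160 nM.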

Compound 3, half-maximal inhibitory concentration: 310 nM
Estimate against measurement, compound 3: 7.8-fold (0.89 log units) below, outside the stated range (above it).
By their numbers in this assay, from the lowest: compounds 1 and 2 (each within the scatter of the next); then compound 3.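

In this assay, replacing thiophen-2-yl with 4-cyanophenyl gives a 16-fold higher number from compound 1 to compound 3 (1.19 log units; beyond the scatter), which shows that the group on this carbon of the five-membered ring with 3 nitrogen can strongly change the measured number. This single change alters two things at once: a five-membered aromatic ring with 1 hetero atom gives way to a six-membered ring of carbon only, and a nitrile is added, so the step cannot separate the two. No measurement here explains the higher number.

A plain phenyl group would help separate the ring change from the nitrile, while an amine or a carboxylic acid in place of the nitrile would test other groups on that ring. On these data alone, it also remains open whether 4-cyanophenyl would have a similar effect with hydrogen in place of ethoxycarbonyl.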